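Swapping the Acyl Ring of an Amide With No Measured Potency

The source may hold more compounds than are shown below. What is called first, only, known or untested is meant among the compounds shown, and "the series" means these compounds.

Of the compounds shown here, three have been measured in an assay for inhibition of HSP60/HSP10 (Homo sapiens), with a stated time of 60 min; on this read-out lower numbers stand for stronger inhibition and higher numbers for weaker inhibition: compound 1 `COc1ccc(Br)cc1C(=O)Nc1ccccc1`, compound 2 `COc1ccccc1C(=O)Nc1ccc(Sc2nc3ccccc3s2)cc1` and compound 3 `COc1ccccc1C(=O)Nc1ccc(Sc2nc3ccccc3s2)c(Cl)c1`. For compound 1 the result is a limit of the assay rather than a number, > 100000 nM. Compound 2 also gives only a limit, > 100000 nM. Compound 3 again gives a limit, > 100000 nM. Among the compounds with values here, compound 2 therefore stands at the edge of what this assay can report, and the one step between measured compounds, a step that the two limits leave unreadable from compound 2 to compound 3, cannot be read in size or direction. All that the measurements show is the limit of > 100000 nM in this assay, at which 3 of the 3 values shown sit.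

Compound 4 `O=C(Nc1ccc(Sc2nc3ccccc3s2)cc1)c1cccc(Br)c1` differs from compound 2 by 3-bromophenyl in place of 2-methoxyphenyl on a carbonyl carbon. Within the data shown here, no measured step covers this exchange of the acyl ring, and the single measured step gives no guide. The expectation therefore rests only on the shared picture of all three measured compounds sitting at the limit. Compound 4 is expected to give about 150000 nM, with a range from 40000 nM to 500000 nM. This amounts to an estimated step that the limit leaves unreadable from compound 2 to compound 4, expected to be no more than the scatter.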

Compound 4, half-maximal inhibitory concentration: > 100000 nM
Compound 4 ended at the assay's limit; the forecaster's own chance of this, stated with the estimate: 75%; the middle value is on the limit's open side.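

The step from compound 2 to compound 4 cannot be read in size or direction, as both results are limits of the assay and not numbers. The compounds shown leave open whether any change to this structure gives a readable potency, as all results so far sit at one limit: the limit of > 100000 nM in this assay, at which 4 of the 4 values shown sit.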